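Methyl for chloro on the aryl amide of a pyridine N-oxide series

The source may report more compounds than this note shows. Statements on the series, on what has been measured and on what is new or still open speak of the compounds shown alone.

Measured so far:
Compound 1, `Cc1cc(C)cc(C(=O)NCN2CCC(c3cccc[n+]3[O-])CC2)c1`: in a functional assay on HEK293 cells for agonist activity at D(4) dopamine receptor (Homo sapiens), read by FLIPR (a higher number here means a larger maximal response, a lower number a smaller maximal response), compound 1 gives 56%.
Compound 2, `Cc1cc(C(=O)NCN2CCC(c3cccc[n+]3[O-])CC2)ccc1Cl`: in this assay compound 2 gives 62%.

Compound 2 holds the higher of the two numbers, yet it is separated from compound 1 only by a number 6 percentage points higher from compound 1 to compound 2 (within the scatter), a difference that stays within the scatter, so the two aryl amides are not distinguishable here. Compound 3, `Cc1ccc(C(=O)NCN2CCC(c3cccc[n+]3[O-])CC2)cc1C`, is the next member and differs from compound 2 by methyl in place of chloro on an aromatic carbon; read one bond further out, 4-chloro-3-methylphenyl becomes 3,4-dimethylphenyl. Within the data shown here, the only step that bears on this change is the exchange of one substituted phenyl for another between compound 1 and compound 2, and it was within the scatter. On that basis no step beyond the scatter is expected; the estimated shift is a number 3 percentage points lower from compound 2 to compound 3 (within the scatter). Compound 3 is therefore expected to give about 59% in this assay, most likely between 46% and 72%.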

Compound 3, largest response reached (reported as efficacy), in percent of the reference or control that the assay uses: 65%
Compound 3: the middle estimate sits 6 percentage points below what was measured; low and high end bracket the measured number.
By their numbers in this assay, from the lowest: compounds 1, 2 and 3 (each within the scatter of the next).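

Chloro and methyl are not told apart at this position, the aromatic carbon ortho to a methyl group and para to a large group: the exchange gives a number 3 percentage points higher from compound 2 to compound 3 (within the scatter) in this assay. The step of a number 9 percentage points higher from compound 1 to compound 3 (within the scatter) adds a second comparison, in which 3,4-dimethylphenyl and 3,5-dimethylphenyl on the same carbonyl carbon also stay within the scatter, so the arrangement of the two methyl groups does not separate these compounds either. No measured evidence is available to account for these results.

The compounds shown leave open whether the response stays in this range with a methoxy group, an amine or a carboxylic acid at this position. They also do not show how an unsubstituted phenyl on the amide would compare with these three aryl groups.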